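Phenyl for thiophene on the triple bond

The compounds below may be only part of what the source reports. "The series", "measured", "known", "first", "only" and "open" are said of these compounds alone.

In a functional assay on HCT-116 cells (Homo sapiens) for antiproliferative activity, with a stated time of 72 h (on this read-out lower numbers stand for stronger inhibition and higher numbers for weaker inhibition), compound 1 `CCCCC#Cc1cc([C@@H]2O[C@H](CO)[C@@H](O)[C@H]2O)n2ncnc(N)c12` gives 2900 nM, and compound 3 `Nc1ncnn2c([C@@H]3O[C@H](CO)[C@@H](O)[C@H]3O)cc(C#Cc3cccs3)c12` gives 65500 nM, the higher of the two exact numbers. Compound 2 `Nc1ncnn2c([C@@H]3O[C@H](CO)[C@@H](O)[C@H]3O)cc(C#Cc3ccc(F)cc3)c12` gives only a limit of the assay, > 100000 nM. Compound 4 `Nc1ncnn2c([C@@H]3O[C@H](CO)[C@@H](O)[C@H]3O)cc(C#Cc3ccccc3)c12` differs from compound 3 as follows: phenyl in place of thiophen-2-yl on a triple-bonded carbon. This puts phenyl in place of thiophen-2-yl on a triple-bonded carbon. Two large steps came with replacing butyl by a ring: an at least 34-fold higher number from compound 1 to compound 2 (1.53 log units; beyond the scatter) and a 23-fold higher number from compound 1 to compound 3 (1.35 log units; beyond the scatter). Exchanging one ring for another gave an at least 1.5-fold lower number from compound 2 to compound 3 (0.18 log units; that floor lies within the scatter), whose floor lies within the scatter. The step expected here is a 1.2-fold higher number from compound 3 to compound 4 (0.09 log units; within the scatter), nothing beyond the scatter. Compound 4 is estimated at 80000 nM, with an expected range from 30000 nM to 200000 nM.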

Compound 4, half-maximal inhibitory concentration: 46900 nM
Estimate against measurement, compound 4: 1.7-fold (0.23 log units) above; measured number inside the range.
By their numbers in this assay, from the lowest: compound 1; then compounds 4 and 3 (each within the scatter of the next). At a limit, above all of these: compound 2.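

In this assay, the unsubstituted phenyl ring behaves much like thiophen-2-yl, with a 1.4-fold lower number from compound 3 to compound 4 (0.15 log units; within the scatter), while butyl stays clearly ahead of it, with a 16-fold higher number from compound 1 to compound 4 (1.21 log units; beyond the scatter). Hydrogen in place of fluoro on the phenyl ring gives an at least 2.1-fold lower number from compound 2 to compound 4 (0.32 log units; beyond the scatter). That step is only a floor, since compound 2 carries a limit of the assay rather than a number: the limit of > 100000 nM in this assay, at which 1 of the 4 values shown sits.

Still open, from the compounds shown here alone, is how a chain longer than butyl would read on the triple bond. So is whether a phenyl ring carrying an amine would come any closer to compound 1.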